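The source may hold more compounds than are shown below. What is called first, only, known or untested is meant among the compounds shown, and "the series" means these compounds.

Measured compounds:
compound 1, `CCNC1=NS(=O)(=O)c2cc(F)ccc2N1`, > 300 uM in a functional assay (aorta) with Rattus norvegicus as the target; a lower number here means that less compound is needed, a higher number that more compound is needed for the effect
compound 2, `CCCNC1=NS(=O)(=O)c2cc(F)ccc2N1`, 166 uM in this assay
compound 3, `CC(C)(C)NC1=NS(=O)(=O)c2cc(Cl)ccc2N1`, 1.4 uM in this assay

The value of compound 1 is a limit of this assay, not a number (the limit of > 300 uM in this assay, at which 1 of the 3 values shown sits). The change from compound 1 to compound 2, (methyl in place of hydrogen on a saturated chain carbon, two bonds along the chain from an amine nitrogen), gives an at least 1.8-fold lower number from compound 1 to compound 2 (0.25 log units; that floor lies within the scatter). Compound 3 stands lowest of the two numbers in this assay; how its core differs from that of compound 1 is not broken down here. Compound 4, `CCC(C)(C)NC1=NS(=O)(=O)c2cc(Cl)ccc2N1`, is not yet measured; it differs from compound 3 by methyl in place of hydrogen on a saturated chain carbon, two bonds along the chain from an amine nitrogen, the same change as from compound 1 to compound 2, at the same place. Resting on an at least 1.8-fold lower number from compound 1 to compound 2 (0.25 log units; that floor lies within the scatter), a step of similar modest size is expected, a 1.8-fold lower number from compound 3 to compound 4 (0.24 log units; within the scatter), for compound 4. Compound 4 is therefore estimated at 0.8 uM in this assay, between 0.3 uM and 2.5 uM.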

Compound 4, concentration for half-maximal effect: 0.29 uM
Compound 4: the middle estimate sits 2.8-fold (0.44 log units) above what was measured; the whole stated range lies above it.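

In this assay, methyl in place of hydrogen on a saturated chain carbon, two bonds along the chain from an amine nitrogen, gives a 4.8-fold lower number from compound 3 to compound 4 (0.68 log units; beyond the scatter). This shows a step beyond the scatter on one core, but not that the step carries over at the same size to the other core: the same change on two cores in this assay, an at least 1.8-fold lower number (0.25 log units; that floor lies within the scatter) from compound 1 to compound 2 and a 4.8-fold lower number (0.68 log units; beyond the scatter) from compound 3 to compound 4; the limit leaves it open whether they differ. Compound 1 gives > 300 uM, which is a limit of the assay and not a number.

The compounds shown leave open whether a longer chain than 1,1-dimethylpropyl on the amine nitrogen would extend the step or reverse it. Also open, from the compounds shown here alone, is how a cyclohexyl group, or a hydroxyl at the chain end, would read in this assay.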